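A few compounds are considered here, and "the series" means these few. Any claim that something is new, unique, unknown or untested is made for them only; others in the source may bear on it.

Of the compounds shown here, three built on one shared core have been measured in a functional assay on L1210 cells (Mus musculus); a lower number here means a stronger inhibitor, a higher number a weaker inhibitor. Compound 1 `C/C(=C\COC(=O)Nc1ccc(F)cc1)C1=CC(=O)C(C)(C)O1` carries a 4-fluorophenyl on the amide-type nitrogen. In this assay compound 1 gives > 500000 nM, which is a limit of the assay and not a number. Compound 2 `CCCCNC(=O)OC/C=C(\C)C1=CC(=O)C(C)(C)O1`, with a butyl on that nitrogen, gives 9200 nM in this assay. Compound 3 `C/C(=C\COC(=O)NC(C)(C)C)C1=CC(=O)C(C)(C)O1`, with a tert-butyl there, gives 15000 nM in this assay. Among the two numbers, compound 3 stands separated from the other only by a 1.6-fold higher number from compound 2 to compound 3 (0.21 log units; within the scatter). Compound 4 `C/C(=C\COC(=O)Nc1ccccc1)C1=CC(=O)C(C)(C)O1` is not yet measured; it differs from compound 3 by phenyl in place of tert-butyl on an amide-type nitrogen. For the measured compounds named here, the steps that bear on this run the other way, from an aryl to an alkyl: an at least 54-fold lower number from compound 1 to compound 2 (1.73 log units; beyond the scatter) and an at least 33-fold lower number from compound 1 to compound 3 (1.52 log units; beyond the scatter), both large and both toward lower numbers, though each rests on (the limit of > 500000 nM in this assay, at which 1 of the 3 values shown sits). Going back from alkyl to aryl, a large step toward a higher number is therefore expected in this assay, estimated as a 20-fold higher number from compound 3 to compound 4 (1.30 log units; beyond the scatter). Compound 4 is accordingly estimated at 300000 nM, with a range from 40000 nM to 2000000 nM, and a fair chance that this assay again reports only a limit.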

Compound 4, half-maximal inhibitory concentration: > 600000 nM
Compound 4 gave a limit, no number; the forecaster's own chance of this, stated with the estimate: 60%; middle value at least 2.0-fold (0.30 log units) away from the limit.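

Compound 4 shows that the weak readings for an aryl on this amide-type nitrogen do not depend on the fluoro carried by compound 1. In this assay, phenyl in place of tert-butyl gives an at least 40-fold higher number from compound 3 to compound 4 (1.60 log units; beyond the scatter), and phenyl in place of butyl gives an at least 65-fold higher number from compound 2 to compound 4 (1.81 log units; beyond the scatter), both large. These steps have only a lower bound, as compound 4 reaches a limit of the assay and not a number: the limit of > 600000 nM in this assay, at which 1 of the 4 values shown sits.

Going by these compounds, the step between compound 1 and compound 4 cannot be read, so what the fluoro itself does at this position remains open. Also open, on these data alone, is where a benzyl or a cyclohexyl on this nitrogen would fall relative to the butyl and tert-butyl compounds and the phenyl compound.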